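The source may hold more compounds than are shown below. What is called first, only, known or untested is meant among the compounds shown, and "the series" means these compounds.

In a functional assay on HL-60 cells (Homo sapiens) for cytotoxicity, read by WST assay, with a stated time of 48 h (a higher number here means that more compound is needed for the effect, a lower number that less compound is needed), compound 1 (`O=C1OC[C@H](Cc2ccccc2)[C@H]1Cc1ccc(OC(F)(F)F)cc1`) gives 27000 nM and compound 2 (`CCCCOc1cc(C[C@H]2C(=O)OC[C@@H]2Cc2ccccc2)ccc1O`) gives 35000 nM while compound 3 (`O=C1OC[C@H](Cc2ccccc2O)[C@H]1Cc1ccc(Cl)c(Cl)c1`) gives 33000 nM in the same read-out. Compound 3 stands within the scatter of both other compounds, and no order can be drawn among the three. Among the measured compounds shown here, compound 4 (`O=C1OC[C@H](Cc2cccc(O)c2)[C@H]1Cc1ccc(Cl)c(Cl)c1`) carries 3-hydroxyphenyl in place of 2-hydroxyphenyl on a saturated chain carbon bound to a saturated ring carbon and has no measurement yet. For the measured compounds named here, no step between measured compounds that differ in one place is available, and the size of this change therefore has no direct measure. The expectation rests on compound 3 at 33000 nM and on all three measured values lying within the scatter of one another. No step beyond the scatter is expected in this assay in either direction. The estimated change a 1.1-fold lower number from compound 3 to compound 4 (0.04 log units; within the scatter) stays within the scatter. Compound 4 is estimated at 30000 nM with an expected range from 14000 nM to 60000 nM in this read-out.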

Compound 4, half-maximal effective concentration: 48000 nM
For compound 4 the middle estimate is 1.6-fold (0.20 log units) below the measured one, and the stated range covers the measured number.
By their numbers in this assay, from the lowest: compounds 1, 3, 2 and 4 (each within the scatter of the next).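

Among the compounds shown here, compound 3 and compound 4 give the first one-place comparison, and it concerns only where the hydroxyl sits on the phenyl group: with 3-hydroxyphenyl in place of 2-hydroxyphenyl on a saturated chain carbon bound to a saturated ring carbon, this assay shows a 1.5-fold higher number from compound 3 to compound 4 (0.16 log units; within the scatter). This swap between the two hydroxyphenyl groups is therefore not separated from the usual scatter in this read-out, although a single pair says nothing about other groups at this position. No measurement on hand bears on an explanation for this result.

As far as these compounds go, whether an aminophenyl or a carboxyphenyl group in the same place would give a step beyond the scatter remains open. From the compounds shown here alone, it is also open whether a plain phenyl on the core of compound 3 would read differently from either hydroxyphenyl group.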